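Swapping One Side Chain: Compound 3 to Compound 4

The source may hold more compounds than are shown below. What is called first, only, known or untested is meant among the compounds shown, and "the series" means these compounds.

Measured in a functional assay on MCF7 cells (Homo sapiens) for inhibition, read by fluorescence, with a stated time of 72 h; a higher number here means a weaker inhibitor, a lower number a stronger inhibitor:
- Compound 1 `Cn1cnc2c(NC(=N)N)ncnc21`: > 100000 nM (a limit, not a number)
- Compound 2 `CC(C)n1cnc2c(N)nc(N)nc21`: > 100000 nM (a limit, not a number)
- Compound 3 `CC(C)n1cnc2c(NC(=N)N)nc(NCCCCCCO)nc21`: 5200 nM

For the measured compounds named here, compound 3 is the only one with a true number, 5200 nM. Compound 4 `CC(C)[C@H](N)COc1nc(NC(=N)N)c2ncn(C(C)C)c2n1` shares its core and changes one group: 2-amino-3-methylbutoxy in place of (6-hydroxyhexyl)amino on an aromatic carbon. Here 2-amino-3-methylbutoxy takes the place of (6-hydroxyhexyl)amino on an aromatic carbon, between two ring nitrogen atoms. Going by the values given here, no measured step shows what such a swap does, so only a small change in this assay is expected, with no firm direction. The expected change is a 1.2-fold lower number from compound 3 to compound 4 (0.06 log units; within the scatter), probably not beyond the scatter. The estimate for compound 4 is 4500 nM, with an expected range of 900 nM to 30000 nM.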

Compound 4, half-maximal inhibitory concentration: 3400 nM
Beside the measured number, compound 4's estimate is 1.3-fold (0.12 log units) above it; measured number inside the range.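

In this assay, for the compounds shown here, replacing the side chain gives a 1.5-fold lower number from compound 3 to compound 4 (0.18 log units; within the scatter) and so shows what the earlier compounds could not: on this aromatic carbon, between two ring nitrogen atoms, 2-amino-3-methylbutoxy and (6-hydroxyhexyl)amino cannot be told apart. Going by these compounds alone, compound 3 and compound 4 are the only pair that can be read as true numbers, and the other values offer no such reading: the limit of > 100000 nM in this assay, at which 2 of the 4 values shown sit. As far as these compounds go, whether a carboxylic acid or a longer chain at this position would shift the number beyond the scatter stays open, as does the effect of the opposite stereocentre in 2-amino-3-methylbutoxy.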